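Removing the Methyl from the Methoxy Group of Compound 2

A few compounds are considered here, and "the series" means these few. Any claim that something is new, unique, unknown or untested is made for them only; others in the source may bear on it.

Three compounds have been measured so far:
compound 1 `O=C(Nc1cccc(-n2cc(-c3ccncc3)c(-c3ccc(Cl)c(O)c3)n2)c1)Nc1cccc(C(F)(F)F)c1`: > 32500 nM in a functional assay on OVCAR-5 cells (Homo sapiens) for inhibition, read by sulforhodamine B assay, with a stated time of 48 h (on this read-out higher numbers stand for lower toxicity in this test and lower numbers for higher toxicity in this test), a limit of the assay
compound 2 `COc1cc(-c2nn(-c3cccc(NC(=O)Nc4cc(C(F)(F)F)cc(C(F)(F)F)c4)c3)cc2-c2ccncc2)ccc1Cl`: 12000 nM in this assay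
compound 3 `COc1cc(-c2nn(-c3cccc(NC(=O)Nc4cccc(C(F)(F)F)c4)c3)cc2-c2ccncc2)ccc1Cl`: > 50000 nM in this assay, a limit of the assay

Within the data shown here, compound 2 holds the only number among the three; the other two values are limits. The change from compound 2 to compound 4 `O=C(Nc1cccc(-n2cc(-c3ccncc3)c(-c3ccc(Cl)c(O)c3)n2)c1)Nc1cc(C(F)(F)F)cc(C(F)(F)F)c1` is hydrogen in place of methyl on an oxygen on an aromatic ring. The same change, taken in the reverse direction, separates compound 1 from compound 3, where a step that the two limits leave unreadable from compound 1 to compound 3. Compound 1 sits at the limit of > 32500 nM in this assay, at which 1 of the 3 values shown sits. Compound 3 sits at the limit of > 50000 nM in this assay, at which 1 of the 3 values shown sits. The size of that step therefore cannot be read. The other measured step, an at least 4.1-fold higher number from compound 2 to compound 3 (0.61 log units; beyond the scatter), concerns a different position and does not bear on the present change. With no readable step of this kind, the expected change in this assay is no change at the digits printed from compound 2 to compound 4 (within the scatter), nothing beyond the scatter. Compound 4 is therefore estimated at 12000 nM, with a range from 4000 nM to 40000 nM.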

Compound 4, concentration lethal to 50% of the cells: 4700 nM
Compound 4: middle estimate off by 2.6-fold (0.41 log units), on the high side; low and high end bracket the measured number.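

In this assay, the change from methoxy to hydroxy on the 4-chloro-3-methoxyphenyl group now has a readable size, and it is a 2.6-fold lower number from compound 2 to compound 4 (0.41 log units; beyond the scatter), so the hydroxy compound carries the higher toxicity in this test. With the hydroxy group in place, adding a second trifluoromethyl group to the urea's aryl ring also moves the number down, and the change is an at least 6.9-fold lower number from compound 1 to compound 4 (0.83 log units; beyond the scatter). Loss of a trifluoromethyl group therefore raises the number in both the methoxy and the hydroxy pair, with no pair among these compounds going against it, although the sizes cannot be told apart: the same change on two cores in this assay, an at least 4.1-fold higher number (0.61 log units; beyond the scatter) from compound 2 to compound 3 and an at least 6.9-fold higher number (0.83 log units; beyond the scatter) from compound 4 to compound 1; the limit leaves it open whether they differ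

Among these compounds, whether methoxy to hydroxy has the same effect with only one trifluoromethyl group stays open, as compound 1 and compound 3 are both limits of the assay and the step between them cannot be read. Also open, on these data alone, is how an amine or a longer chain such as ethoxy would read in place of the hydroxy group of compound 4.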